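The source may hold more compounds than are shown below. What is called first, only, known or untested is meant among the compounds shown, and "the series" means these compounds.

Compound 3 `N[C@H]1CC[C@@H](N(C[C@H]2Cc3ccccc3CN2)[C@H]2CCCc3cccnc32)CC1` stands highest among the three compounds measured in an ADME assay on microsomes from liver (Homo sapiens) for metabolic stability (a lower number here means that less of the compound is left, a higher number that more of the compound is left), where compound 3 gives 86%. Its nearest neighbour is compound 1 `C/C(CN(C[C@H]1Cc2ccccc2CN1)[C@H]1CCCc2cccnc21)=C(\F)CN`, for which this assay gives 51%, and the furthest is compound 2 `N[C@H]1CC[C@H](CN(C[C@H]2Cc3ccccc3CN2)[C@H]2CCCc3cccnc32)CC1`, for which this assay gives 39%; the steps of a number 35 percentage points higher from compound 1 to compound 3 (beyond the scatter) and a number 47 percentage points higher from compound 2 to compound 3 (beyond the scatter) are both beyond the scatter.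

Compound 4 `N[C@H]1CC[C@H](N(C[C@H]2Cc3ccccc3CN2)[C@H]2CCCc3cccnc32)CC1` keeps every atom and bond of compound 3 and differs only as follows: the two compounds have the same atoms and bonds and differ only in configuration as drawn: 2 of 4 stereo elements differ; a stereocentre at a saturated ring carbon is drawn R in compound 3 and S in compound 4; a stereocentre at a saturated ring carbon is drawn s in compound 3 and r in compound 4. Among the measured compounds shown here, none of the measured steps bears on such a change in configuration: a number 12 percentage points lower from compound 1 to compound 2 (beyond the scatter), a number 35 percentage points higher from compound 1 to compound 3 (beyond the scatter) and a number 47 percentage points higher from compound 2 to compound 3 (beyond the scatter) all involve a different group on the amine nitrogen, not a change in the drawn arrangement of the 4-aminocyclohexyl. With the atoms and bonds unchanged, the step of a number 10 percentage points lower from compound 3 to compound 4 (within the scatter) is expected to be small, most likely within the scatter, with a slight downward lean because compound 3 sits at the top of the range at 86%. Compound 4 is therefore estimated to give 76% in this assay, in a range from 55% to 92%.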

Compound 4, percent of the compound remaining: 95%
Beside the measured number, compound 4's estimate is 19 percentage points below it; the measured number lies above the stated range.
By their numbers in this assay, from the lowest: compound 2; then compound 1; then compounds 3 and 4 (each within the scatter of the next).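

In this assay, among the compounds shown here, redrawing the configuration of the 4-aminocyclohexyl gives a number 9 percentage points higher from compound 3 to compound 4 (within the scatter), so the two drawn arrangements of this group, which the earlier compounds did not compare, are not told apart here. The step can be laid to one change alone: the fact that compounds 3 and 4 differ only in the configuration as drawn. The high numbers therefore hold for 4-aminocyclohexyl on the amine nitrogen in both drawn configurations, with a number 56 percentage points higher from compound 2 to compound 4 (beyond the scatter) when it stands in place of (4-aminocyclohexyl)methyl and a number 44 percentage points higher from compound 1 to compound 4 (beyond the scatter) when it stands in place of 4-amino-3-fluoro-2-methylbut-2-en-1-yl.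

The compounds shown leave open whether this holds when a hydroxyl group or an amide takes the place of the amine on the cyclohexyl. They also leave open whether the drawn configuration of (4-aminocyclohexyl)methyl would matter any more than it does for 4-aminocyclohexyl.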